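The compounds below may be only part of what the source reports. "The series", "measured", "known", "first", "only" and "open" are said of these compounds alone.

For the measured compounds named here, in a physicochemical assay for lipophilicity, read by HPLC, at pH 7.4 (a lower number here means a more polar compound, a higher number a more lipophilic compound), compound 2 `CCC/N=C1\S/C(=C\c2ccc(O)cn2)C(=O)N1c1ccccc1C` gives 3, the highest of the three numbers so far. Compound 1 `CCC/N=C1\S/C(=C\c2ccc(O)c(Cl)c2)C(=O)N1C1CCS(=O)(=O)CC1` gives 2.6, and compound 3 `CCC/N=C1\S/C(=C\c2ccc(O)c(Cl)c2)C(=O)N1C1CCN(C)C(=O)C1` gives 0.6. The next compound, compound 4 `CCC/N=C1\S/C(=C\c2ccc(O)c(Br)c2)C(=O)N1c1ccccc1C`, has not yet been measured. It differs from compound 2 at a single place, on a double-bonded chain carbon bound to a double-bonded ring carbon: 3-bromo-4-hydroxyphenyl in place of 5-hydroxypyridin-2-yl on a double-bonded chain carbon bound to a double-bonded ring carbon. Going by the values given here, only one measured step is available, a number 2.00 log units lower from compound 1 to compound 3 (beyond the scatter). It is large, but it concerns a different place, an amide-type nitrogen in a ring, so it shows only that a single replacement can move this assay far and gives no direct measure of this change. The estimate therefore rests on the structural change itself, in which a ring with a hetero atom gives way to a ring of carbon only and bromine enters. The expected change is upward and smaller than that large step, namely a number 1.20 log units higher from compound 2 to compound 4 (beyond the scatter). Compound 4 is estimated at 4.2, with an expected range of 3.6 to 4.8.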

Compound 4, distribution coefficient: 3.9
Beside the measured number, compound 4's estimate is 0.30 log units above it; low and high end bracket the measured number.
By their numbers in this assay, from the lowest: compound 3; then compound 1; then compound 2; then compound 4.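

In this assay, the place on a double-bonded chain carbon bound to a double-bonded ring carbon now has a measured step of its own, a number 0.90 log units higher from compound 2 to compound 4 (beyond the scatter), whereas the earlier step concerned an amide-type nitrogen in a ring. This modest step shows that replacing 5-hydroxypyridin-2-yl with 3-bromo-4-hydroxyphenyl can move the number at this place, but the loss of the ring nitrogen and the entry of bromine are read together and cannot be separated. Nothing measured here accounts for the step.

On these data alone, it remains open whether the same replacement would give a step of similar size with 1,1-dioxothian-4-yl or 1-methyl-2-oxopiperidin-4-yl on the amide-type nitrogen in a ring. Also open, as far as these compounds go, is how an amine or a carboxylic acid at the chain-carbon place would move the number.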